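The compounds below may be only part of what the source reports. "The series", "measured", "known", "first", "only" and "open" are said of these compounds alone.

Of the compounds shown here, three have been measured so far: compound 1 `NC(=O)CNCc1ccccc1`, compound 2 `C[C@@H](NCc1ccc(OCc2ccccc2)cc1)C(N)=O` and compound 3 `CNC(=O)[C@@H](C)NCc1ccc(OCc2ccccc2)cc1`.

In a functional assay on the whole organism with Mus musculus as the target (on this read-out lower numbers stand for an effect already at smaller amounts and higher numbers for an effect only at larger amounts of compound), compound 1 gives 490 mg/kg. Compound 2 gives 23.8 mg/kg in this assay, and compound 3 gives 40.5 mg/kg. For the measured compounds named here, compound 3 thus stands second highest of the three numbers; its nearest neighbour is compound 2, and the single measured step, a 1.7-fold higher number from compound 2 to compound 3 (0.23 log units; within the scatter), is within the scatter. Compound 1 lies furthest away, at a number beyond the scatter from compound 3.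

Compound 4 `NC(=O)[C@@H](CO)NCc1ccc(OCc2ccccc2)cc1` has not yet been measured. It differs from compound 3 in one place: 1-carbamoyl-2-hydroxyethyl in place of 1-(methylcarbamoyl)ethyl on an amine nitrogen. Going by the values given here, no measured step bears on this exchange of one side chain for another on the amine nitrogen; the only step at hand, a 1.7-fold higher number from compound 2 to compound 3 (0.23 log units; within the scatter), concerns the amide-type nitrogen instead and is within the scatter. Compound 4 keeps the shared core of compounds 2 and 3, which both give numbers far from that of compound 1. The step of a 1.1-fold higher number from compound 3 to compound 4 (0.05 log units; within the scatter) is therefore expected to stay within the scatter, with no preferred direction. In this assay compound 4 is estimated at 45 mg/kg, in the range 15 mg/kg to 140 mg/kg, with wide uncertainty.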

Compound 4, dose for half-maximal effect: 133 mg/kg
Compound 4: middle estimate off by 3.0-fold (0.47 log units), on the low side, within the range that was stated.
By their numbers in this assay, from the lowest: compounds 2 and 3 (each within the scatter of the next); then compound 4; then compound 1.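

In this assay, the exchange of 1-(methylcarbamoyl)ethyl for 1-carbamoyl-2-hydroxyethyl on the amine nitrogen moves the number beyond the scatter (a 3.3-fold higher number from compound 3 to compound 4 (0.52 log units; beyond the scatter)), which the methyl on the amide-type nitrogen did not do. The narrower change, hydroxy in place of hydrogen on a saturated chain carbon, two bonds along the chain from an amine nitrogen and a carbonyl carbon, also raises the number beyond the scatter (a 5.6-fold higher number from compound 2 to compound 4 (0.75 log units; beyond the scatter)), so this side chain is sensitive to a single added hydroxy. No measurement at hand accounts for this rise.

On these data alone, it remains open whether an amine or a methoxy group in place of that hydroxy, or a longer chain carrying it, would bring the number back towards that of compound 2. As far as these compounds go, it is also open what a methyl on the amide-type nitrogen would do on the hydroxy-bearing side chain.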